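Swapping a dimethylphenyl for a fluorophenyl in compound 1

The source may hold more compounds than are shown below. What is called first, only, known or untested is meant among the compounds shown, and "the series" means these compounds.

Of the compounds shown here, three have been measured in a physicochemical assay for solubility, with a stated time of 18 h, at pH 7.4; on this read-out lower numbers stand for lower solubility and higher numbers for higher solubility. Compound 1 `COc1ccc(F)cc1CNCCCNc1ccnc2cc(Cc3cc(C)cc(C)c3)ccc12` gives 4200 nM, the lowest of the three numbers. Compound 2 `c1ccc(Oc2ccc3c(NCCCNCc4ccco4)ccnc3c2)cc1` gives 14500 nM, and compound 3 `c1ccc(-c2ccc3c(NCCCNCc4ccco4)ccnc3c2)cc1` gives 32000 nM, so compound 1 sits at the bottom, with compound 2 nearest to it and compound 3 furthest away.

Among the measured compounds shown here, the only single-point step among the measured compounds is a 2.2-fold higher number from compound 2 to compound 3 (0.34 log units; beyond the scatter). That step concerns a different part of the molecule from the one altered here and does not share the core of compound 1, so it gives no direct guidance.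

Compound 4 `COc1ccc(F)cc1CNCCCNc1ccnc2cc(Cc3ccc(F)cc3)ccc12` differs from compound 1 in one place: 4-fluorophenyl in place of 3,5-dimethylphenyl on a saturated chain carbon bound to an aromatic carbon. For the measured compounds named here, no measured pair shows this exchange, so there is nothing to say how the number in this assay should move. With the core and the rest of the molecule unchanged, the expected step from compound 1 to compound 4 is small, a 1.3-fold higher number from compound 1 to compound 4 (0.12 log units; within the scatter), and may well fall within the usual scatter.

Compound 4 is therefore estimated to show 5500 nM in this assay, with a likely range from 2500 nM to 12000 nM.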

Compound 4, solubility: 4200 nM
Compound 4: middle estimate off by 1.3-fold (0.12 log units), on the high side, within the range that was stated.
By their numbers in this assay, from the lowest: compounds 1 and 4 (each within the scatter of the next); then compound 2; then compound 3.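

In this assay, among the compounds shown here, the exchange of 3,5-dimethylphenyl for 4-fluorophenyl gives no change at the digits printed from compound 1 to compound 4 (within the scatter) and so provides the first measured pair that bears on this position, on a saturated chain carbon bound to an aromatic carbon. Both groups are six-membered aromatic rings of carbon only, with no hydrogen-bond donors or acceptors and no net charge, and on the shared core this exchange of two methyl groups for one fluorine leaves the two compounds indistinguishable on this read-out. The data offer no explanation for this result.

For the compounds shown here, this single pair covers only two closely matched aromatic groups, so it cannot show whether the position would tolerate any other replacement equally well, such as a ring carrying a carboxylic acid or a dimethylamino group, or a saturated morpholine ring in place of the aromatic ring. It also leaves open whether the same exchange would read the same way on a different core, such as the one with the furan-bearing side chain.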